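Iodo in place of ethynyl on a nucleoside core

The source may report more compounds than this note shows. Statements on the series, on what has been measured and on what is new or still open speak of the compounds shown alone.

Compound 1 `COc1ncnc2c1c(-c1ccsc1)cn2[C@@H]1O[C@H](CO)[C@@H](O)[C@H]1O`: 90 nM
Compound 2 `C#Cc1cn([C@@H]2O[C@H](CO)[C@@H](O)[C@H]2O)c2ncnc(OC)c12`: 300 nM

Among the compounds with values here, in a functional assay on K562 cells (Homo sapiens), read by MTT assay, with a stated time of 72 h (a higher number here means a weaker inhibitor, a lower number a stronger inhibitor), compound 2 gives 300 nM, the higher of the two numbers measured so far; compound 1 gives 90 nM. Within the data shown here, the one measured step, a 3.3-fold higher number from compound 1 to compound 2 (0.52 log units; beyond the scatter), shows that the group on this carbon matters. Compound 3 `COc1ncnc2c1c(I)cn2[C@@H]1O[C@H](CO)[C@@H](O)[C@H]1O` differs from compound 2 by iodo in place of ethynyl on an aromatic carbon. Among the measured compounds shown here, no measured step involves iodo, so no step beyond the scatter is expected in this assay, though the range is wide. Compound 3 is estimated at 300 nM, between 100 nM and 1500 nM. The expected step is no change at the digits printed from compound 2 to compound 3 (within the scatter).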

Compound 3, half-maximal inhibitory concentration: > 20000 nM
Compound 3 gave a limit, no number (the forecaster's own chance of this, stated with the estimate: 5%); middle value at least 66-fold (1.82 log units) from the limit.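

Compound 3 gives a limit, not a number: the limit of > 20000 nM in this assay, at which 1 of the 3 values shown sits. Even so, iodo in place of ethynyl gives an at least 66-fold higher number from compound 2 to compound 3 (1.82 log units; beyond the scatter), and iodo in place of thiophen-3-yl gives an at least 220-fold higher number from compound 1 to compound 3 (2.34 log units; beyond the scatter). Both steps are large, whereas the step between the two earlier groups was modest, so this carbon separates the groups far more sharply than those two compounds alone suggested.

The compounds shown leave open how an amine or a longer chain on this carbon would behave. They also cannot tell whether iodo stands alone in giving such a weak result.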